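This account rests on a few compounds, and the source may have more. Where it says the series, first, only, none or still open, it means among the compounds named here.

Measured so far in an in vitro assay on BHK cells for binding affinity to growth hormone secretagogue receptor type 1 (Homo sapiens); on this read-out higher numbers stand for weaker inhibition and lower numbers for stronger inhibition:

Compound 1 `CN(C)CCCN1C(=O)[C@H](c2ccccc2)N(Cc2ccc(-c3ccccc3-c3nn[nH]n3)cc2)C1=S` gives 35000 nM.
Compound 2 `CN(C)c1ccc(N2C(=O)[C@H](CCc3ccccc3)N(Cc3ccc(-c4ccccc4-c4nn[nH]n4)cc3)C2=S)cc1` gives only a limit, > 100000 nM, not a number.
Compound 3 `CN(C)CCCN1C(=O)[C@H](CCc2ccccc2)N(Cc2ccc(-c3ccccc3-c3nn[nH]n3)cc2)C1=O` gives 4000 nM.

Compound 3 stands lowest of the two numbers on this assay. Among the measured compounds shown here, its nearest neighbour is compound 1, whose number is higher by a margin beyond the scatter; the two differ in more than one place, so no single step is drawn between them, and only the two values themselves are compared here. Compound 2 contributes a limit at the top of the range, (the limit of > 100000 nM in this assay, at which 1 of the 3 values shown sits), and nothing more.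

The next compound, compound 4 `O=C1[C@H](CCc2ccccc2)N(Cc2ccc(-c3ccccc3-c3nn[nH]n3)cc2)C(=O)N1CCCN1CCCCC1`, is not yet measured. It differs from compound 3 as follows: piperidin-1-yl in place of dimethylamino on a saturated chain carbon, three bonds along the chain from an amide-type nitrogen in a ring. The change sits on the chain carried by the ring nitrogen, at the far end from the core, and keeps a basic amine there, now within a ring. No comparable exchange is available among the measured compounds, so the expectation rests on compound 3 alone.

The expected step in this assay, a 1.3-fold lower number from compound 3 to compound 4 (0.12 log units; within the scatter), is small, within or just beyond the scatter, and if anything towards a lower number. Compound 4 is therefore estimated at 3000 nM, expected between 1000 nM and 10000 nM.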

Compound 4, half-maximal inhibitory concentration: 600 nM
Estimate against measurement, compound 4: 5.0-fold (0.70 log units) above, and the stated range ends above it.
By their numbers in this assay, from the lowest: compound 4; then compound 3; then compound 1. At a limit, above all of these: compound 2.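

In this assay, the step to a 3-(piperidin-1-yl)propyl chain from a 3-(dimethylamino)propyl chain is a 6.7-fold lower number from compound 3 to compound 4 (0.82 log units; beyond the scatter) and lies beyond the scatter, so the amine at the far end of this chain affects the read-out even though both compounds keep an amine there. Among the compounds shown here, this is the first exchange that can be read at a single place, since the earlier compounds differ from each other in more than one place and could not isolate this position. For the compounds shown here, the single step gives the direction for this one exchange on this one core, and nothing at hand bears on what causes it.

The compounds shown do not separate the effect of closing the ring from that of the extra carbons, which pyrrolidin-1-yl, morpholin-4-yl or diethylamino at the same chain end could begin to resolve. Also open, going by these compounds, are whether a shorter or longer chain carrying the piperidin-1-yl group shifts the number, and whether the same exchange holds on the sulfur-bearing cores of compound 1 and compound 2.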